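An Acetyl-to-Dimethylamino Swap in a Cell Toxicity Test

The source may report more compounds than this note shows. Statements on the series, on what has been measured and on what is new or still open speak of the compounds shown alone.

Compound 1 `COc1cc(C)cc(-c2c(-c3ccnc(-c4ccc(C(C)=O)cc4)c3)cnn2CC#N)c1` gives > 100000 nM in a functional assay on HOP-92 cells (Homo sapiens) for inhibition, read by sulforhodamine B assay, with a stated time of 48 h; on this read-out lower numbers stand for higher toxicity in this test and higher numbers for lower toxicity in this test.
Compound 2 `Cc1cc(O)cc(-c2nn(CC#N)cc2-c2ccnc(-c3ccc(Oc4ccccc4)cc3)c2)c1` gives 39500 nM in this assay.

For compound 1 the entry is only a limit of the test, not a measured number, namely (the limit of > 100000 nM in this assay, at which 1 of the 2 values shown sits). Compound 2 differs from compound 1 in more than one place, so its value stands beside that of compound 1 without a counted step between them.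

Compound 3 `COc1cc(C)cc(-c2c(-c3ccnc(-c4ccc(N(C)C)cc4)c3)cnn2CC#N)c1` is compound 1 with dimethylamino in place of acetyl on an aromatic carbon. Going by the values given here, no measured pair shows this change, so nothing beyond the usual scatter is expected; the expected step is a number no higher from compound 1 to compound 3 (the limit leaves the size open). Compound 3 is therefore estimated at 100000 nM, between 30000 nM and 300000 nM, with a fair chance that the test again reports only a limit.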

Compound 3, concentration lethal to 50% of the cells: > 100000 nM
Compound 3: a limit, no number (the forecaster's own chance of this, stated with the estimate: 60%); the middle value sits exactly at the limit.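

Compound 1 and compound 3 both end at a limit of the test rather than a number, so no step between them can be read: the limit of > 100000 nM in this assay, at which 2 of the 3 values shown sit.

Going by these compounds, whether dimethylamino in place of acetyl changes the toxicity reading in this assay, and by how much, stays open.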